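From phenyl to 2,4-dimethylphenyl on the thiocarbonyl nitrogen

The compounds below may be only part of what the source reports. "The series", "measured", "known", "first", "only" and "open" are said of these compounds alone.

Compound 1 `COc1ccc2c(c1)/C(=N/NC(=S)N1CCN(c3ccccc3)CC1)C(=O)N2`: in a functional assay on A549 cells (Homo sapiens) for inhibition, read by MTT assay, with a stated time of 72 h (on this read-out lower numbers stand for stronger inhibition and higher numbers for weaker inhibition), compound 1 gives 7520 nM.
Compound 2 `O=C1Nc2ccccc2/C1=N/NC(=S)Nc1ccccc1`: in this assay compound 2 gives > 100000 nM, which is a limit of the assay.
Compound 3 `O=C1Nc2ccc(Cl)cc2/C1=N/NC(=S)Nc1ccccc1`: in this assay compound 3 gives 33100 nM.

Compound 3 holds the highest of the two numbers reported in this assay, with compound 1 sitting lower. Among the compounds with values here, the one single-point step measured, chloro in place of hydrogen on an aromatic carbon, gave an at least 3.0-fold lower number from compound 2 to compound 3 (0.48 log units; beyond the scatter) and starts from a limit (the limit of > 100000 nM in this assay, at which 1 of the 3 values shown sits). Compound 4 `Cc1ccc(NC(=S)N/N=C2\C(=O)Nc3ccc(Cl)cc32)c(C)c1` differs from compound 3 by 2,4-dimethylphenyl in place of phenyl on an amide-type nitrogen. Within the data shown here, no measured step touches the group on that nitrogen, and compound 1, which carries a different group there, is separated from compound 3 by more than one change. A step within the scatter is therefore expected, a 1.3-fold lower number from compound 3 to compound 4 (0.12 log units; within the scatter). Compound 4 is estimated at 25000 nM, within 8000 nM to 80000 nM.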

Compound 4, half-maximal inhibitory concentration: > 100000 nM
Compound 4: only a limit was reported; the forecaster's own chance of this, stated with the estimate: 15%; at least 4.0-fold (0.60 log units) between middle value and limit.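

Within the data shown here, compound 3 to compound 4 is the first measured step at the amide-type nitrogen, and it shows that this position is not neutral in this assay: 2,4-dimethylphenyl in place of phenyl gives an at least 3.0-fold higher number from compound 3 to compound 4 (0.48 log units; beyond the scatter), opposite in direction to an at least 3.0-fold lower number from compound 2 to compound 3 (0.48 log units; beyond the scatter). Compound 4 gives > 100000 nM, which is a limit of the assay. The full size of the step therefore stays unknown: the limit of > 100000 nM in this assay, at which 2 of the 4 values shown sit.

The compounds shown leave open whether a single methyl on the phenyl would give the same step. As far as these compounds go, how a saturated amine such as piperidine would read on that nitrogen also remains open.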